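The compounds below may be only part of what the source reports. "The series", "measured", "known", "first", "only" and "open" are said of these compounds alone.

In a functional assay on L5178Y cells (Mus musculus) for inhibition, read by MTT assay, with a stated time of 24 h (on this read-out higher numbers stand for weaker inhibition and lower numbers for stronger inhibition), compound 1 `Oc1ccc([C@@H]2C/C(=N\Nc3ccccc3)c3c(O)cc(O)cc3O2)cc1` gives >= 11300 nM as a limit of the assay and not a number. Compound 2 `Cn1cccc1/C=N/N=C1\C[C@@H](c2ccc(O)cc2)Oc2cc(O)cc(O)c21` gives >= 11300 nM, which is also a limit. Compound 3 `O=C(N/N=C1\C[C@@H](c2ccc(O)cc2)Oc2cc(O)cc(O)c21)c1cccs1` gives >= 11300 nM, again a limit and not a number. Going by the values given here, the whole picture so far is the limit of >= 11300 nM in this assay, at which 3 of the 3 values shown sit, and no compound stands apart from it.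

The next compound changes the group carried by the carbonyl of compound 3. Compound 4 `O=C(Cc1c[nH]c2ccccc12)N/N=C1\C[C@@H](c2ccc(O)cc2)Oc2cc(O)cc(O)c21` differs by (1H-indol-3-yl)methyl in place of thiophen-2-yl on a carbonyl carbon and is thus a case of (1H-indol-3-yl)methyl in place of thiophen-2-yl on a carbonyl carbon. The measured steps offer little to go on. There is a step that the two limits leave unreadable from compound 1 to compound 3 and there is a step that the two limits leave unreadable from compound 2 to compound 3 and there is also a step that the two limits leave unreadable from compound 1 to compound 2 and none of these has a size that can be carried over to the new change.

Because compound 3 gives >= 11300 nM as a limit, no step beyond the usual scatter is expected in this assay and no direction can be named. The expected step is a number no higher from compound 3 to compound 4 (the limit leaves the size open) and it is read against a limit. Compound 4 is estimated at 11300 nM with an expected range from 4500 nM to 25000 nM and it will most likely be reported as a limit again.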

Compound 4, half-maximal inhibitory concentration: >= 11300 nM
Compound 4: no number, only a limit; the forecaster's own chance of this, stated with the estimate: 70%; the middle value sits exactly at the limit.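

In this assay compound 4 gives >= 11300 nM, a limit of the assay and not a number. Compound 3 also rests on a limit, so the step between the two cannot be read. The compounds shown leave open how strongly any of them inhibits, and whether any change to the group on the carbonyl carbon matters: the limit of >= 11300 nM in this assay, at which 4 of the 4 values shown sit.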